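This account rests on a few compounds, and the source may have more. Where it says the series, first, only, none or still open, it means among the compounds named here.

Three compounds share one core and differ only in the length of a saturated chain attached to an aromatic nitrogen. Compound 1 `CCCCCCCCn1cc(COC[C@@H]2OC[C@H](N)[C@H]2O)nn1` and compound 2 `CCCCCCCCCn1cc(COC[C@@H]2OC[C@H](N)[C@H]2O)nn1` carry the shorter chains, while compound 3 `CCCCCCCCCCCCCCn1cc(COC[C@@H]2OC[C@H](N)[C@H]2O)nn1` carries the longest of the three measured. In a functional assay on MGC-803 cells (Homo sapiens) for antiproliferative activity, read by MTT assay, with a stated time of 48 h (a higher number here means a weaker inhibitor, a lower number a stronger inhibitor), compound 1 reaches only the limit of the assay, > 128000 nM. Compound 2 likewise gives only a limit, > 128000 nM. Going by the values given here, compound 3 is the sole compound with an actual number here, giving 8790 nM in this assay. The step that the two limits leave unreadable from compound 1 to compound 2 cannot be read since both values sit at the limit (the limit of > 128000 nM in this assay, at which 2 of the 3 values shown sit). The two readable steps both point the same way: an at least 14-fold lower number from compound 1 to compound 3 (1.16 log units; beyond the scatter) and an at least 14-fold lower number from compound 2 to compound 3 (1.16 log units; beyond the scatter), each large and well beyond the scatter, so that lengthening the chain has so far gone with a lower number.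

Compound 4 `CCCCCCCCCCCCCCCCCCn1cc(COC[C@@H]2OC[C@H](N)[C@H]2O)nn1` continues in that direction: butyl in place of hydrogen on a saturated chain carbon, ten or more bonds along the chain from an aromatic nitrogen. Among the compounds with values here, with only one real number to build on, the expectation is a further lowering, a 2.2-fold lower number from compound 3 to compound 4 (0.34 log units; beyond the scatter), though its size is uncertain. Compound 4 is therefore estimated to give about 4000 nM in this assay, within a range from 1200 nM to 14000 nM.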

Compound 4, half-maximal inhibitory concentration: 3110 nM
Compound 4: the middle estimate sits 1.3-fold (0.11 log units) above what was measured, and the stated range covers the measured number.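

Adding butyl on a saturated chain carbon continues the trend in this assay with a 2.8-fold lower number from compound 3 to compound 4 (0.45 log units; beyond the scatter), a modest step but one beyond the scatter, and this is the first comparison here between two real numbers rather than a number and a limit. Against the shorter chains, the result is an at least 41-fold lower number from compound 2 to compound 4 (1.61 log units; beyond the scatter) and an at least 41-fold lower number from compound 1 to compound 4 (1.61 log units; beyond the scatter), both large, and no readable step among the four compounds goes against the pattern of a longer chain giving a lower number. These two sizes are only bounds, not exact steps, because compound 1 and compound 2 each give a limit and not a number: the limit of > 128000 nM in this assay, at which 2 of the 4 values shown sit.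

As far as these compounds go, it remains open whether a chain longer than that of compound 4 would lower the number further or reverse the trend, and at what length between the chains of compound 2 and compound 3 a real number first appears. From the compounds shown here alone, it is also open whether a chain ending in a carboxylic acid or a phenyl ring would behave like these plain saturated chains.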